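Compound 4: methyl on the carboxymethoxy chain

A few compounds are considered here, and "the series" means these few. Any claim that something is new, unique, unknown or untested is made for them only; others in the source may bear on it.

In a functional assay on HL-60 cells (Homo sapiens) for antiproliferative activity, with a stated time of 72 h (a lower number here means a stronger inhibitor of growth, a higher number a weaker inhibitor of growth), compound 2 `C=C(CC)C(=O)c1ccc(OCC(=O)O)cc1Cl` gives only a limit, > 60000 nM. Compound 1 `C=C(C)C(=O)c1ccc(OCC(=O)O)cc1Cl` likewise gives a limit, > 60000 nM. Compound 3 `C=C(CC)C(=O)c1ccc(OCC(=O)O)cc1C` also gives a limit, > 60000 nM. The steps a step that the two limits leave unreadable from compound 1 to compound 2 and a step that the two limits leave unreadable from compound 2 to compound 3 are thus unreadable, and the whole set sits at the limit of > 60000 nM in this assay, at which 3 of the 3 values shown sit. Compound 4 `C=C(CC)C(=O)c1ccc(OC(C)C(=O)O)cc1Cl` differs from compound 2 by methyl in place of hydrogen on a saturated chain carbon bound to a carbonyl carbon and an oxygen on an aromatic ring. Going by the values given here, no measured step touches this chain carbon, and no measured step reads at all, so the three limits are the only guide and nothing argues for a move beyond the scatter. Compound 4 is therefore expected to stay at the limit, with an estimated value of 80000 nM, ranging from 30000 nM to 200000 nM. The implied step that the limit leaves unreadable from compound 2 to compound 4 is an estimate only.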

Compound 4, concentration for 50% growth inhibition: > 60000 nM
Compound 4: a limit, no number; the forecaster's own chance of this, stated with the estimate: 85%; the middle value does not contradict the limit.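

Going by these compounds alone, compound 2 and compound 4 both give only a limit in this assay, so no step between them can be read. The compounds shown leave open whether any change to the shared core yields a measurable growth-inhibition value.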